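Notes on the step from compound 3 to compound 4

The compounds below may be only part of what the source reports. "The series", "measured", "known", "first", "only" and "open" are said of these compounds alone.

All compounds here carry the shared core and differ in one group on its ring of carbon only. In a functional assay on KB cells (Homo sapiens) for antiproliferative activity, read by sulforhodamine B assay, with a stated time of 3 days (a higher number here means a weaker inhibitor of growth, a lower number a stronger inhibitor of growth), compound 3 (`O=C(Nc1cccc(Nc2ncc(F)c(Nc3ccc(F)cc3)n2)c1)c1cnccn1`) gives 23600 nM. In this assay compound 1 (`O=C(Nc1ccccn1)c1cccc(Nc2ncc(F)c(Nc3ccc(F)cc3)n2)c1`) gives 20000 nM. The two stand level: a 1.2-fold higher number from compound 1 to compound 3 (0.07 log units; within the scatter). Compound 2 (`O=C(Nc1nccs1)c1cccc(Nc2ncc(F)c(Nc3ccc(F)cc3)n2)c1`) gives > 10000 nM, which is a limit of the assay and not a number. That leaves two steps without a size: a step that the limit leaves unreadable from compound 1 to compound 2 and a step that the limit leaves unreadable from compound 2 to compound 3.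

Compound 4 (`O=C(c1cccc(Nc2ncc(F)c(Nc3ccc(F)cc3)n2)c1)N1CCCCC1`) carries (piperidin-1-yl)carbonyl in place of ((pyrazin-2-yl)carbonyl)amino on an aromatic carbon, meta to a large group: (piperidin-1-yl)carbonyl in place of ((pyrazin-2-yl)carbonyl)amino on an aromatic carbon. Going by the values given here, no measured compound has a non-aromatic ring at this place, so the new group itself is untested. Among the compounds with values here, for compound 4 the expectation rests on a 1.2-fold higher number from compound 1 to compound 3 (0.07 log units; within the scatter), the only readable change at this place. No step beyond the scatter is therefore expected in this assay, though the uncertainty is wide and a limit, as with compound 2, is possible. The estimated step is a 1.2-fold lower number from compound 3 to compound 4 (0.07 log units; within the scatter). The expected value for compound 4 is 20000 nM, with an estimated range of 8000 nM to 50000 nM.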

Compound 4, concentration for 50% growth inhibition: 14800 nM
Compound 4: middle estimate off by 1.4-fold (0.13 log units), on the high side; measured number inside the range.
By their numbers in this assay, from the lowest: compounds 4, 1 and 3 (each within the scatter of the next).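

In this assay, the first non-aromatic ring at this place, (piperidin-1-yl)carbonyl, with 0 hydrogen-bond donors against 1 in ((pyrazin-2-yl)carbonyl)amino, leaves the number within the scatter: a 1.6-fold lower number from compound 3 to compound 4 (0.20 log units; within the scatter), and a 1.4-fold lower number from compound 1 to compound 4 (0.13 log units; within the scatter). Among compound 1, compound 3 and compound 4, neither an aromatic ring in the group nor a hydrogen-bond donor on it therefore separates the readings, and no readable step at this position yet lies beyond the scatter. Compound 2 stands at a limit of the assay and not at a number, so its steps to the other compounds cannot be read: the limit of > 10000 nM in this assay, at which 1 of the 4 values shown sits.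

Open, on these data alone, is whether a carboxylic acid or a piperazin-1-yl ring at this place would give a step beyond the scatter, as every readable step here lies within it. Also open, as far as these compounds go, is whether the level readings of compound 1, compound 3 and compound 4 would hold with another group elsewhere on the shared core, or in cells other than those of this assay.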